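A few compounds are considered here, and "the series" means these few. Any claim that something is new, unique, unknown or untested is made for them only; others in the source may bear on it.

Compound 1 `Cc1cnc(Nc2ccc(C(=O)Nc3c(C)cccc3C)cc2)nc1-c1ccc(OC(F)(F)F)cc1` gives 1.3 nM in an assay on NIH3T3 cells for inhibition of Sonic hedgehog protein (Mus musculus), read by a luciferase reporter, with a stated time of 48 h; a higher number here means a weaker inhibitor, a lower number a stronger inhibitor. Going by the values given here, compound 2 `Cc1cnc(Nc2ccc(C(=O)Nc3c(C)cccc3C)cc2)nc1-c1ccc(C#N)cc1` gives 2.8 nM in this assay, the higher of the two numbers, with compound 1 as its nearest neighbour; the one step between them, a 2.2-fold higher number from compound 1 to compound 2 (0.33 log units; beyond the scatter), was modest. Compound 3 `Cc1cnc(Nc2ccc(C(=O)Nc3c(C)cccc3C)cc2)nc1-c1ccc(F)cc1` differs from compound 2 by fluoro in place of cyano on an aromatic carbon. Among the compounds with values here, no measured step touches a fluoro group, so only the cyano-bearing compound 2 and the modest step from compound 1 bear on the question. Compound 3 is therefore expected to sit near compound 2, with a 1.4-fold higher number from compound 2 to compound 3 (0.15 log units; within the scatter) as the estimated step, giving an expected value of 4 nM with a range of 1.5 nM to 12 nM.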

Compound 3, half-maximal inhibitory concentration: 2.2 nM
Compound 3: the middle estimate sits 1.8-fold (0.26 log units) above what was measured; low and high end bracket the measured number.
By their numbers in this assay, from the lowest: compounds 1, 3 and 2 (each within the scatter of the next, the first and the last beyond it).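

On the aromatic carbon para to a large group, this assay gives a 1.3-fold lower number from compound 2 to compound 3 (0.10 log units; within the scatter) for fluoro in place of cyano, so removing the hydrogen-bond acceptor counted on cyano moves the number by no more than the scatter. Fluoro in place of trifluoromethoxy gives a 1.7-fold higher number from compound 1 to compound 3 (0.23 log units; within the scatter) and so compound 3 is not separated from either neighbour, even though those two lie beyond the scatter of each other. No measurement shown explains these small steps. As far as these compounds go, whether this position also accepts an amine, a carboxylic acid or a longer chain remains open.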